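A few compounds are considered here, and "the series" means these few. Any claim that something is new, unique, unknown or untested is made for them only; others in the source may bear on it.

Compound 1 `COc1cc(OC)c(-c2coc3cc(OCC=C(C)C)ccc3c2=O)cc1OC` carries a 3-methylbut-2-en-1-yl chain on an oxygen on an aromatic ring of the shared core. Within the data shown here, in a functional assay on A-375 cells (Homo sapiens) for antiproliferative activity, read by MTT assay, with a stated time of 24 h (on this read-out higher numbers stand for weaker inhibition and lower numbers for stronger inhibition), compound 1 gives 1580 nM, the only plain number among the three measured compounds. Of the three measured values, two rest at the limit of > 10000 nM in this assay, at which 2 of the 3 values shown sit. Compound 2 `COc1cccc(C(=O)Oc2ccc3c(=O)c(-c4cc(OC)c(OC)cc4OC)coc3c2)c1` has a (3-methoxyphenyl)carbonyl group in that place. In this assay compound 2 gives > 10000 nM, which is a limit of the assay and not a number. Compound 3 `COc1cc(OC)c(-c2coc3cc(OCc4ccccc4C(F)(F)F)ccc3c2=O)cc1OC` has a 2-(trifluoromethyl)benzyl group there. In this assay compound 3 gives > 10000 nM, again a limit. The steps read an at least 6.3-fold higher number from compound 1 to compound 2 (0.80 log units; beyond the scatter) and an at least 6.3-fold higher number from compound 1 to compound 3 (0.80 log units; beyond the scatter), while a step that the two limits leave unreadable from compound 2 to compound 3.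

Compound 4 `COc1cc(OC)c(-c2coc3cc(OCc4ccccc4Cl)ccc3c2=O)cc1OC` is not yet measured. It differs from compound 1 in this way: 2-chlorophenyl in place of 2-methylprop-1-en-1-yl on a saturated chain carbon bound to an oxygen on an aromatic ring. That change closely resembles the one behind an at least 6.3-fold higher number from compound 1 to compound 3 (0.80 log units; beyond the scatter), so a weakening of similar size is expected here. Compound 4 is therefore expected to give 10000 nM. For compound 4 the expected range runs from 3000 nM to 30000 nM. The expected step reads a 6.3-fold higher number from compound 1 to compound 4 (0.80 log units; beyond the scatter).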

Compound 4, half-maximal inhibitory concentration: 2020 nM
Compound 4: the middle estimate sits 5.0-fold (0.69 log units) above what was measured; measured number outside the range, below it.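

Swapping the 3-methylbut-2-en-1-yl chain for 2-chlorobenzyl gives a 1.3-fold higher number from compound 1 to compound 4 (0.11 log units; within the scatter) in this assay, so an aromatic ring on this saturated chain carbon does not by itself cost activity. Changing only trifluoromethyl to chloro on an aromatic carbon gives an at least 4.9-fold lower number from compound 3 to compound 4 (0.69 log units; beyond the scatter), which ties the loss in compound 3 to that group and not to the benzyl frame as a whole. Replacing (3-methoxyphenyl)carbonyl with 2-chlorobenzyl gives an at least 4.9-fold lower number from compound 2 to compound 4 (0.69 log units; beyond the scatter), and this step and the one before it both start from a limit of the assay and not a number, so their full size stays unknown: the limit of > 10000 nM in this assay, at which 2 of the 4 values shown sit.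

The compounds shown leave open how a plain benzyl, 2-fluorobenzyl or 2-methylbenzyl group would read on this oxygen. Also open, going by these compounds, is the effect of a longer chain ending in an amine or a carboxylic acid.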